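The source may report more compounds than this note shows. Statements on the series, on what has been measured and on what is new or still open speak of the compounds shown alone.

Compounds measured so far:
compound 1, `C=CCNC(=O)/C=C/c1ccccc1`, 63%
compound 2, `CCCCCNC(=O)/C=C/c1ccccc1`, 60%
compound 3, `O=C(/C=C/c1ccccc1)NCc1ccc(Cl)cc1`, 6%

In a functional assay on the whole organism for inhibition, with Brassica rapa subsp. chinensis as the target, with a stated time of 3 days, tested at 100 ppm (on this read-out higher numbers stand for more inhibition of growth at the one concentration tested and lower numbers for less inhibition of growth), compound 1 gives the highest of the three numbers. Compound 2 comes nearest, with a number 3 percentage points lower from compound 1 to compound 2 (within the scatter). Compound 3 stands furthest away, and its value shows a much weaker inhibition than that of compound 1.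

The next compound, compound 4, `CCC(C)OC(=O)/C=C/c1ccccc1`, has not yet been measured. It differs from compound 1 in one place: sec-butoxy in place of allylamino on a carbonyl carbon. The amide of compound 1 thus becomes an ester in compound 4.

Within the data shown here, of the measured steps, only the step from compound 1 to compound 2 touches the same part of the molecule, and it varies merely the chain on the nitrogen while keeping the amide; it was within the scatter. Among the measured compounds shown here, no measured step exchanges the amide nitrogen for an oxygen, so no direct guide exists for the change to compound 4. With that in mind, compound 4 is expected to show a moderate downward step, a number 18 percentage points lower from compound 1 to compound 4 (beyond the scatter), with wide uncertainty. The estimate for compound 4 in this assay is 45%, with a range from 15% to 75%.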

Compound 4, percent growth inhibition at one concentration: 18%
Compound 4: middle estimate off by 27 percentage points, on the high side; low and high end bracket the measured number.
By their numbers in this assay, from the lowest: compound 3; then compound 4; then compounds 2 and 1 (each within the scatter of the next).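

In this assay, the exchange on the carbonyl carbon gives a number 45 percentage points lower from compound 1 to compound 4 (beyond the scatter), whereas the earlier change on the nitrogen chain, which kept the amide, gave only a number 3 percentage points lower from compound 1 to compound 2 (within the scatter), so growth inhibition depends on what is attached at the carbonyl carbon far more than the earlier pair could show. This single exchange alters several things at once: the nitrogen and the amide hydrogen leave, an oxygen enters, and the unbranched allyl chain with its double bond gives way to the sec-butyl chain, so compound 1 and compound 4 alone cannot separate the linking atom from the chain. Nothing available accounts for the size of this drop.

The compounds shown leave open how sec-butylamino, which would pair the same chain with the amide nitrogen, and allyloxy, which would pair the allyl chain with the ester oxygen, would compare with compound 1 and compound 4. They also leave open how a free carboxylic acid or a simple methyl ester at the same carbonyl carbon would stand in this assay.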